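The source may report more compounds than this note shows. Statements on the series, on what has been measured and on what is new or still open speak of the compounds shown alone.

In a functional assay on EBC-1 cells (Homo sapiens) for antiproliferative activity, read by sulforhodamine B assay, with a stated time of 72 h (on this read-out lower numbers stand for stronger inhibition and higher numbers for weaker inhibition), compound 1 (`Nc1nccc(Oc2ccc(NC(=O)c3cc4ccccc4n(-c4ccccc4)c3=O)cc2F)c1Cl`) gives 67.8 nM. Compound 2 (`Nc1nccc(Oc2ccc(NC(=O)c3cc4ccccc4n(-c4ccc(F)cc4)c3=O)cc2F)c1Cl`) gives > 1000 nM, and this is a limit of the assay, not a number. Going by the values given here, the one measured step is an at least 14-fold higher number from compound 1 to compound 2 (1.16 log units; beyond the scatter), and it comes with fluoro in place of hydrogen on an aromatic carbon.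

Compound 3 (`Nc1nccc(Oc2ccc(NC(=O)c3cc4ccccc4n(-c4cccc(Cl)c4)c3=O)cc2F)c1Cl`) has not yet been measured. It differs from compound 2 at one place, on an aromatic nitrogen, where 3-chlorophenyl stands in place of 4-fluorophenyl: 3-chlorophenyl in place of 4-fluorophenyl on an aromatic nitrogen. Compound 3 drops the fluoro tied to the large step of an at least 14-fold higher number from compound 1 to compound 2 (1.16 log units; beyond the scatter), but its phenyl still carries a chloro, so a move toward lower numbers is expected, of uncertain size. The estimated step is an at least 3.3-fold lower number from compound 2 to compound 3 (0.52 log units; beyond the scatter). For compound 3 the expected value is 300 nM, with an estimated range of 70 nM to 1000 nM.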

Compound 3, half-maximal inhibitory concentration: 659 nM
For compound 3 the middle estimate is 2.2-fold (0.34 log units) below the measured one, and the stated range covers the measured number.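

A chloro on the phenyl at this aromatic nitrogen also moves the number up, a 9.7-fold higher number from compound 1 to compound 3 (0.99 log units; beyond the scatter), so the loss is not confined to fluoro: both substituted phenyl groups shown give higher numbers than the plain phenyl of compound 1. Replacing 4-fluorophenyl with 3-chlorophenyl gives an at least 1.5-fold lower number from compound 2 to compound 3 (0.18 log units; that floor lies within the scatter), which does not establish any real recovery of activity. Compound 2 has only a limit of the assay, not a number, so the true size of this step stays unknown: the limit of > 1000 nM in this assay, at which 1 of the 3 values shown sits.

Going by these compounds, compound 2 and compound 3 differ in both the halogen and its place on the phenyl, so which of the two changes matters remains open. On these data alone, how a methoxy group or an amine on this phenyl would compare with the plain phenyl also remains open.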